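Replacing the 3,3-dimethyloxiran-2-yl group of compound 3

A few compounds are considered here, and "the series" means these few. Any claim that something is new, unique, unknown or untested is made for them only; others in the source may bear on it.

Measured in a functional assay on Jurkat cells (Homo sapiens) for cytotoxicity, with a stated time of 72 h (on this read-out higher numbers stand for an effect only at larger amounts of compound and lower numbers for an effect already at smaller amounts), all three values being limits:
- compound 1 `C=C[C@@](C)(/C=C/c1ccc(OS(=O)(=O)C(F)(F)F)cc1)CCC=C(C)C` gives > 49000 nM as a limit
- compound 2 `C=C[C@@](C)(/C=C/c1ccc(OS(=O)(=O)c2ccc(C)cc2)cc1)CCC=C(C)C` gives > 49000 nM as a limit
- compound 3 `C=C[C@@](C)(/C=C/c1ccc(O)cc1)CCC1OC1(C)C` gives > 49000 nM as a limit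

Compound 3 stands with the others, and the whole picture is the limit of > 49000 nM in this assay, at which 3 of the 3 values shown sit, without any exact number. Compound 4 `C=C[C@@](C)(/C=C/c1ccc(O)cc1)CC/C=C(C)/C=N/N` carries one structural change: a group of 6 heavy atoms (4 carbon, 2 nitrogen; no ring) in place of a group of 5 heavy atoms (4 carbon, 1 oxygen; one three-membered non-aromatic ring with 1 hetero atom), on a saturated chain carbon, three bonds along the chain from two double-bonded chain carbons is what separates it from compound 3. For the measured compounds named here, the only measured step is a step that the two limits leave unreadable from compound 1 to compound 2 and it offers no size to carry over. It also concerns a different part of the molecule. The expectation therefore stays close to the limit of compound 3, with only a modest shift toward smaller amounts, and the expected step is an at least 1.2-fold lower number from compound 3 to compound 4 (0.08 log units; that floor lies within the scatter) in this uncertain setting. For compound 4 the estimated value is 40000 nM with an expected range from 12000 nM to 80000 nM and a real chance of another limit.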

Compound 4, half-maximal effective concentration: > 49000 nM
Compound 4 ended at the assay's limit; the forecaster's own chance of this, stated with the estimate: 55%; middle value at least 1.2-fold (0.08 log units) from the limit.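

No step from compound 3 to compound 4 can be read, because both values are limits, as is every value shown: the limit of > 49000 nM in this assay, at which 4 of the 4 values shown sit.

The compounds shown leave open at what amount, if any, each one becomes cytotoxic.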